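The compounds below may be only part of what the source reports. "The series", "measured", "known", "first", "only" and "open" are said of these compounds alone.

Measured compounds:
Compound 1 `COc1cc(OC)c2c(=O)cc(-c3ccc(OC4CCN(C)CC4)cc3)oc2c1`, in a functional assay (Homo sapiens) for antiproliferative activity, read by resazurin assay, with a stated time of 48 h, tested at 10 uM (a lower number here means a weaker effect, a higher number a stronger effect of the compound at the concentration tested), compound 1 gives 49%.
Compound 2 `COc1cc(OC)c2c(=O)cc(-c3ccc(OCCCN(C)C)cc3)oc2c1`, in this assay compound 2 gives 59%.
Compound 3 `COc1cc(OC)c2c(=O)cc(-c3ccc(Br)cc3)oc2c1`, in this assay compound 3 gives 10%.

Compound 3 gives the lowest of the three numbers: the step is a number 39 percentage points lower from compound 1 to compound 3 (beyond the scatter) and a number 49 percentage points lower from compound 2 to compound 3 (beyond the scatter), both beyond the scatter, whereas between compound 1 and compound 2 the step is only a number 10 percentage points higher from compound 1 to compound 2 (within the scatter). Compound 4 `COc1cc(OC)c2c(=O)cc(-c3ccc(-c4ccc(F)nc4)cc3)oc2c1` differs from compound 3 in one place: 6-fluoropyridin-3-yl in place of bromo on an aromatic carbon. The two measured steps that lead to compound 3 both remove a basic amine-bearing ether and leave bromo, and both are large downward steps; the change to compound 4 instead replaces bromo with an aromatic ring, a group unlike either of the ether side chains, so those steps do not show directly what to expect. Compound 4 is estimated to lie somewhat above compound 3, an expected step of a number 12 percentage points higher from compound 3 to compound 4 (beyond the scatter), which may still fall within the scatter; the estimate for compound 4 in this assay is 22%, between 2% and 48%.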

Compound 4, a percentage reported as inhibition, at one concentration (the size of the read-out at that concentration, not a potency): 6%
The estimate for compound 4 lay 16 percentage points above the measured number, within the range that was stated.
By their numbers in this assay, from the lowest: compounds 4 and 3 (each within the scatter of the next); then compounds 1 and 2 (each within the scatter of the next).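

In this assay, 6-fluoropyridin-3-yl brings an aromatic ring with a hydrogen-bond acceptor to this aromatic carbon, para to a large group, in place of a single bromine atom, and the step is a number 4 percentage points lower from compound 3 to compound 4 (within the scatter). Compared with the two ether side chains, the steps remain large: a number 53 percentage points lower from compound 2 to compound 4 (beyond the scatter) and a number 43 percentage points lower from compound 1 to compound 4 (beyond the scatter). Among these four compounds, the two with an amine-bearing ether therefore stand apart from the two without one, now including a compound with an added aromatic ring, and no compound shown goes against this.

Nothing available explains this separation. On these data alone, it remains open whether a 6-fluoropyridin-3-yl ring carrying a dimethylaminomethyl group, or a piperazine on the aromatic carbon without the ether oxygen, would match the ether side chains in this assay.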